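Chloro for trifluoromethyl on a sulfonamide side chain

The source may report more compounds than this note shows. Statements on the series, on what has been measured and on what is new or still open speak of the compounds shown alone.

Measured compounds:
Compound 1 `CC(C)=CCC1Cc2c(OCCCNS(=O)(=O)c3ccc(Cl)cc3)cc(=O)n(CCCO)c2CC1(C)C` — 24.7%
Compound 2 `CC(C)=CCC/C(C)=C/CC1Cc2c(OCCCNS(=O)(=O)c3ccc(C(F)(F)F)cc3)cc(=O)n(CCCO)c2CC1(C)C` — 26.4%

Of the compounds shown here, two have been tested in a functional assay on PANC-1 cells (Homo sapiens) for inhibition, read by MTT assay, with a stated time of 24 h, tested at 10 uM; on this read-out lower numbers stand for less inhibition and higher numbers for more inhibition at the one concentration tested (going by the name of the read-out). Compound 1 gives 24.7% and compound 2 gives 26.4%. Compound 2 shows the highest of the two numbers, yet its nearest neighbour, compound 1, lies within the scatter of it, so no order can be read between them. For the measured compounds named here, the two differ in more than one place, so no single step between them is drawn.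

Compound 3 `CC(C)=CCC/C(C)=C/CC1Cc2c(OCCCNS(=O)(=O)c3ccc(Cl)cc3)cc(=O)n(CCCO)c2CC1(C)C` has not yet been measured in this assay . It is derived from compound 2 by one change: chloro in place of trifluoromethyl on an aromatic carbon. Compound 1 carries the same chloro group and gives a number within the scatter of compound 2, so no step beyond the scatter is expected from compound 2 to compound 3, in either direction, an estimated a number 0.9 percentage points lower from compound 2 to compound 3 (within the scatter). Compound 3 is therefore expected to give about 25.5%, within a range from 14% to 37%.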

Compound 3, a percentage reported as inhibition, at one concentration (the size of the read-out at that concentration, not a potency): 14.5%
Compound 3: the middle estimate sits 11 percentage points above what was measured; the range from low to high includes it.
By their numbers in this assay, from the lowest: compound 3; then compounds 1 and 2 (each within the scatter of the next).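

In this assay, for the compounds shown here, chloro in place of trifluoromethyl on an aromatic carbon, para to a large group, is the first single change that can be read, and it gives a number 11.9 percentage points lower from compound 2 to compound 3 (beyond the scatter). With chloro held fixed, 3-methylbut-2-en-1-yl in place of hydrogen on a saturated chain carbon bound to a double-bonded chain carbon also registers, giving a number 10.2 percentage points lower from compound 1 to compound 3 (beyond the scatter). Both steps are modest, and they show that each of these two places can move the number, which the earlier pair, differing in more than one place, could not show.

Nothing given here accounts for either step. As far as these compounds go, whether a fluoro, methoxy or nitrile group on this aromatic carbon would follow chloro or trifluoromethyl remains open, as does whether trifluoromethyl would give the same step on the shorter chain.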